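The source may hold more compounds than are shown below. What is called first, only, known or untested is meant among the compounds shown, and "the series" means these compounds.

Values in a functional assay on NIH3T3 cells (Mus musculus) for inhibition, read by MTT assay, with a stated time of 72 h; a higher number here means a weaker inhibitor, a lower number a stronger inhibitor:
- compound 1 `C=C1CC[C@H]2[C@@](C)(CC[C@@H](OC(C)=O)[C@@]2(C)C(=O)OC)[C@@H]1CCC1=CCOC1=O`: 80600 nM
- compound 2 `C=C1CC[C@H]2[C@@](C)(CC[C@@H](OC(C)=O)[C@@]2(C)C(=O)OCc2ccccc2)[C@@H]1CCC1=CCOC1=O`: 12900 nM
- compound 3 `C=C1CC[C@H]2[C@@](C)(CC[C@@H](O)[C@@]2(C)C(=O)OC)[C@@H]1CCC1=CCOC1=O`: 60600 nM
- compound 4 `C=C1CC[C@H]2[C@@](C)(CC[C@@H](O)[C@@]2(C)C(=O)OCc2ccccn2)[C@@H]1CCC1=CCOC1=O`: not yet measured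

Compound 3 and compound 1 lie within the scatter of each other at the high end of these three numbers, while compound 2 lies lower, beyond the scatter from both.

The change to compound 4 is pyridin-2-yl in place of hydrogen on a saturated chain carbon bound to an oxygen next to a carbonyl group. In other words, methyl becomes (pyridin-2-yl)methyl.

The closest measured change is a 6.2-fold lower number from compound 1 to compound 2 (0.80 log units; beyond the scatter), with phenyl in place of hydrogen at the same place. The other measured change, a 1.3-fold lower number from compound 1 to compound 3 (0.12 log units; within the scatter), is hydrogen in place of acetyl on an oxygen on a saturated carbon, so the first step may well carry over to compound 3. For the measured compounds named here, no measured compound carries pyridin-2-yl, so a lower number of similar or somewhat smaller size is expected in this assay. The expected move is a 4.0-fold lower number from compound 3 to compound 4 (0.61 log units; beyond the scatter). Compound 4 is estimated at 15000 nM, with an expected range of 6000 nM to 40000 nM.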

Compound 4, half-maximal inhibitory concentration: 79800 nM
Beside the measured number, compound 4's estimate is 5.3-fold (0.73 log units) below it; the whole stated range lies below it.
By their numbers in this assay, from the lowest: compound 2; then compounds 3, 4 and 1 (each within the scatter of the next).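

In this assay, pyridin-2-yl on a saturated chain carbon bound to an oxygen next to a carbonyl group gives a 1.3-fold higher number from compound 3 to compound 4 (0.12 log units; within the scatter), so methyl to (pyridin-2-yl)methyl brings no readable change in a compound with hydrogen on the oxygen on a saturated carbon. The gain seen with phenyl at the same place, a 6.2-fold lower number from compound 1 to compound 2 (0.80 log units; beyond the scatter), therefore does not carry over to this step, although the two steps differ both in the entering ring and in acetyl or hydrogen on that other oxygen. No measurement at hand bears on this contrast.

Whether the contrast follows the ring or the acetyl stays open, as neither phenyl with hydrogen on that oxygen nor pyridin-2-yl with acetyl on it is among the compounds shown. Also open, on these data alone, is how a longer chain in place of methyl, or a carboxylic acid in place of the ester, would read in this assay.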